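The source may report more compounds than this note shows. Statements on the series, on what has been measured and on what is new or still open speak of the compounds shown alone.

Measured compounds:
compound 1 `COc1ccc(C)cc1NC(=O)CSc1nnc(-c2ccoc2C)n1Cc1ccco1` — 2510 nM
compound 2 `CC(=O)c1ccc(NC(=O)CSc2nnc(-c3ccoc3C)n2Cc2ccco2)cc1` — 2510 nM

In a functional assay on CHO cells for antagonist activity at Orexin/Hypocretin receptor type 1 (Homo sapiens), read by FLIPR and calcium flux (a higher number here means a weaker inhibitor, a lower number a stronger inhibitor), compound 2 sits level with compound 1, since the step of no change at the digits printed from compound 1 to compound 2 (within the scatter) stays within the scatter. Compound 3 `Cc1occc1-c1nnc(SCC(N)=O)n1Cc1ccco1` differs from compound 2 by hydrogen in place of 4-acetylphenyl on an amide-type nitrogen. Among the compounds with values here, the only measured step on this nitrogen exchanged one aryl group for another and left the reading unchanged; no measured pair shows the aryl group removed altogether, so that step gives no direct guide. The expectation for compound 3 is therefore uncertain, leaning toward weaker inhibition, with a step of a 3.2-fold higher number from compound 2 to compound 3 (0.50 log units; beyond the scatter) expected. Compound 3 is estimated at 8000 nM, within 2500 nM to 25000 nM.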

Compound 3, inhibition constant: > 15800 nM
Compound 3: only a limit was reported; the forecaster's own chance of this, stated with the estimate: 25%; at least 1.9-fold (0.29 log units) between middle value and limit.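

Hydrogen in place of the aryl group on the amide-type nitrogen gives a step beyond the scatter (an at least 6.2-fold higher number from compound 2 to compound 3 (0.79 log units; beyond the scatter); likewise an at least 6.2-fold higher number from compound 1 to compound 3 (0.79 log units; beyond the scatter)), whereas the aryl-for-aryl exchange gave none. An aryl group on this nitrogen therefore matters to the reading, with either of the two aryl groups shown. The reading of compound 3 is a limit, not a number: the limit of > 15800 nM in this assay, at which 1 of the 3 values shown sits.

On these data alone, how far compound 3 truly lies from compound 1 and compound 2 stays open. Also open, as far as these compounds go, is whether methyl or benzyl on this nitrogen would hold the reading of the aryl compounds.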